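The compounds below may be only part of what the source reports. "The series", "measured", "known", "first", "only" and "open" are said of these compounds alone.

In an ADME assay on HPC cells (Homo sapiens) for cytotoxicity, with a stated time of 24 h (on this read-out higher numbers stand for lower toxicity in this test and lower numbers for higher toxicity in this test), compound 1 (`CN(C)c1ccc(/C=C2\CCC/C(=C\c3cccc([N+](=O)[O-])c3)C2=O)cc1`) reports > 400000 nM, which is a limit of the assay and not a number. For the measured compounds named here, compound 2 (`O=C1/C(=C/c2ccccc2)CCC/C1=C\c1ccc([N+](=O)[O-])cc1`) gives 123000 nM, the only actual number so far, so it has no measured neighbour to be ranked against. Compound 3 (`O=C1/C(=C/c2ccc(F)cc2)CCC/C1=C\c1ccc([N+](=O)[O-])cc1`) changes compound 2 in one place, with fluoro in place of hydrogen on an aromatic carbon, phenyl to 4-fluorophenyl (fluoro in place of hydrogen on an aromatic carbon). Going by the values given here, no measured step shows how such a change behaves in this assay, so this expectation rests on compound 2 at 123000 nM alone. The expected 1.1-fold lower number from compound 2 to compound 3 (0.05 log units; within the scatter) is small, within the usual scatter, with neither direction favoured. Compound 3 is estimated at 110000 nM, with an expected range from 50000 nM to 250000 nM in this test.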

Compound 3, half-maximal cytotoxic concentration: > 400000 nM
Compound 3 gave a limit, no number (the forecaster's own chance of this, stated with the estimate: 10%); at least 3.6-fold (0.56 log units) between middle value and limit.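

Fluoro in place of hydrogen, on an aromatic carbon para to a large group, is the first change here that can be read as a step in this assay, and it gives an at least 3.2-fold higher number from compound 2 to compound 3 (0.51 log units; beyond the scatter). In this assay compound 3 reports > 400000 nM, which is a limit of the assay and not a number. The step therefore gives only a minimum size and no end point, and the limit is now shared by most of the compounds shown: the limit of > 400000 nM in this assay, at which 2 of the 3 values shown sit.

The compounds shown leave open whether chloro or methoxy in the same place, or an amine, would shift the read-out in the same direction as fluoro. From the compounds shown here alone, they also leave open how far past its limit compound 3 lies, so the full size of this change stays unknown.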